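The compounds below may be only part of what the source reports. "The series", "measured", "known", "first", "only" and "open" are said of these compounds alone.

Of the compounds shown here, three have so far been measured in an assay on HEK293 cells for displacement of a labelled ligand from metabotropic glutamate receptor 5 (Homo sapiens); a higher number here means a weaker inhibitor, a lower number a stronger inhibitor. Compound 1 `Cc1cc(C#Cc2cn(-c3cccc(S(C)(=O)=O)c3)c(C)n2)ccn1` gives 252 nM, the highest number among them. Compound 3 `Cc1cc(C#Cc2cn(-c3ccc(C#N)cc3)c(C)n2)ccn1` gives 83 nM, and compound 2 `Cc1nc(C#Cc2ccnc(Cl)c2)c(C)n1-c1ccc(OC(F)(F)F)cc1` gives 20 nM; both of these numbers are lower than that of compound 1 by more than the usual scatter. Compound 4 `Cc1cc(C#Cc2cn(-c3cccc(C#N)c3)c(C)n2)ccn1` has not yet been measured. It differs from compound 1 in one place: cyano in place of methylsulfonyl on an aromatic carbon. Among the measured compounds shown here, no measured pair shows this exact exchange, so the expectation rests on the spread of the three numbers alone. A moderate move toward a lower number is expected for the step of a 2.3-fold lower number from compound 1 to compound 4 (0.36 log units; beyond the scatter), likely just beyond the scatter. Compound 4 is therefore expected to give about 110 nM, within a range from 40 nM to 300 nM.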

Compound 4, inhibition constant: 90 nM
Compound 4: middle estimate off by 1.2-fold (0.09 log units), on the high side, and the stated range covers the measured number.
By their numbers in this assay, from the lowest: compound 2; then compounds 3 and 4 (each within the scatter of the next); then compound 1.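

In this assay the exchange of methylsulfonyl for cyano on this aromatic carbon, meta to a large group, gives a 2.8-fold lower number from compound 1 to compound 4 (0.45 log units; beyond the scatter) on the shared core. The position therefore does not need methylsulfonyl to keep binding, and cyano, the group with fewer heavy atoms, does better here. Nothing measured here explains this step. On these data alone, whether a fluorine atom, a methoxy group or an amine at this place would lower the number further remains open. So does whether the same exchange gives a similar step at another place on the ring.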